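One More Methyl on the Amide Chain of Compound 3

The source may hold more compounds than are shown below. What is called first, only, known or untested is meant among the compounds shown, and "the series" means these compounds.

Three amides have been measured in an assay on isolated protein for agonist activity at melatonin receptor type 1C (Xenopus laevis), read by spectrophotometry; on this read-out lower numbers stand for an effect already at smaller amounts and higher numbers for an effect only at larger amounts of compound. Compound 1 `COc1ccc(F)c(CNC(C)=O)c1` gives 1950 nM, and compound 2 `CCC(=O)NCc1cc(OC)ccc1F` gives 2400 nM. Compound 2 differs from compound 1 by methyl in place of hydrogen on a saturated chain carbon bound to a carbonyl carbon, and the resulting step is a 1.2-fold higher number from compound 1 to compound 2 (0.09 log units; within the scatter). Compound 3 `CCC(=O)NCCCc1ccc(OC)c(F)c1` is built on a different core; the difference between the two cores is not broken down here. In this assay compound 3 gives 871 nM, the lowest of the three numbers, with the steps to compound 1 and to compound 2 both beyond the scatter.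

Compound 4 `CCCC(=O)NCCCc1ccc(OC)c(F)c1` has not yet been measured. It differs from compound 3 by methyl in place of hydrogen on a saturated chain carbon, two bonds along the chain from a carbonyl carbon. This is the same kind of change as that from compound 1 to compound 2, but not the same: there the entering methyl sits on a saturated chain carbon bound to a carbonyl carbon, here on a saturated chain carbon two bonds along the chain from a carbonyl carbon. Within the data shown here, with only that one earlier example as a guide, and because that step a 1.2-fold higher number from compound 1 to compound 2 (0.09 log units; within the scatter) stayed within the scatter, the step from compound 3 to compound 4 in this assay is expected to be small as well, estimated as a 1.1-fold higher number from compound 3 to compound 4 (0.06 log units; within the scatter). Compound 4 is therefore expected to give about 1000 nM in this assay, with an estimated range from 400 nM to 2500 nM.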

Compound 4, half-maximal effective concentration: 417 nM
For compound 4 the middle estimate is 2.4-fold (0.38 log units) above the measured one; the range from low to high includes it.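

In this assay, methyl in place of hydrogen on a saturated chain carbon, two bonds along the chain from a carbonyl carbon, gives a 2.1-fold lower number from compound 3 to compound 4 (0.32 log units; beyond the scatter) as a modest step that, taken alone, lies beyond the scatter. Set beside the earlier step on the other core, however, it cannot be told apart from that step: the same change on two cores in this assay, a 1.2-fold higher number (0.09 log units; within the scatter) from compound 1 to compound 2 and a 2.1-fold lower number (0.32 log units; beyond the scatter) from compound 3 to compound 4, 2.6-fold (0.41 log units) apart, within the scatter of two such steps

Among these compounds, this shows no dependence of the change on the core, but it does not show that the change carries over unaltered from one core to the other: only two pairs stand here, and the entering methyl does not sit in the same place in them, on a saturated chain carbon bound to a carbonyl carbon in the first pair and two bonds along the chain from a carbonyl carbon in the second.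

The compounds shown leave open whether a longer chain on the amide, such as a butyl or pentyl group, or a branched one such as isopropyl, would extend the step seen with compound 4. Among the compounds shown here, they also leave open what the chain of compound 4 would give on the core of compound 1, the one comparison that would place the methyl identically on both cores.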